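Ethyl Ester of Compound 1 in a Cytotoxicity Read-out

The source may report more compounds than this note shows. Statements on the series, on what has been measured and on what is new or still open speak of the compounds shown alone.

Measured compounds:
compound 1, `COc1ccc(/C=C/C(=O)O)cc1OC(=O)c1nc(C)c(C)nc1C`: 41.3%
compound 2, `CCOC(=O)/C=C/c1ccc(OC(=O)c2nc(C)c(C)nc2C)c(O)c1`: 75.7%

The read-out is a functional assay on EA.hy 926 cells (Homo sapiens) for cytotoxicity, read by MTT assay, with stated times of 24 h and 12 h, tested at 12.5 uM; on this read-out lower numbers stand for a weaker effect and higher numbers for a stronger effect at the one concentration tested. Compound 1 stands lowest of the two numbers in this assay; its nearest neighbour, compound 2, lies higher by a gap beyond the usual scatter. Compound 2 differs from compound 1 in more than one place, so the two values show only that the ethyl ester with its own substitution pattern gives the stronger effect, not what any single change does.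

Compound 3, `CCOC(=O)/C=C/c1ccc(OC)c(OC(=O)c2nc(C)c(C)nc2C)c1`, is the unmeasured compound. It differs from compound 1 by ethyl in place of hydrogen on an oxygen next to a carbonyl group, the carboxy group becoming an ethoxycarbonyl group. Within the data shown here, no pair of measured compounds differs in this one place alone, so the size of the step rests on expectation. Compound 3 is expected to give 58% in this assay, with a range from 40% to 78%. That estimate means an expected step of a number 16.7 percentage points higher from compound 1 to compound 3 (beyond the scatter), a rise probably beyond the scatter but smaller than the gap to compound 2.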

Compound 3, a percentage reported as activity, at one concentration (the size of the read-out at that concentration, not a potency): 26.4%
For compound 3 the middle estimate is 31.6 percentage points above the measured one; measured number below the stated range.
By their numbers in this assay, from the lowest: compound 3; then compound 1; then compound 2.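

In this assay, among these compounds, the exchange of hydrogen for ethyl on the oxygen next to the carbonyl group, which turns the carboxy group into an ethoxycarbonyl group, gives a number 14.9 percentage points lower from compound 1 to compound 3 (beyond the scatter) and is the first change here that can be read in one place alone. It shows that at this position the ethoxycarbonyl group does not by itself bring a stronger effect than the carboxy group on the core of compound 1, so the high number of compound 2, which differs from compound 1 in more than one place, cannot be credited to the ethyl ester alone. Nothing available here accounts for the direction of this step.

Going by these compounds, whether a methyl ester, a longer chain such as butyl on the same oxygen, or a primary amide in place of the ester would lie nearer to compound 1 or to compound 3 stays open. Also open, on these data alone, is whether the same exchange of hydrogen for ethyl would lower the number on a core carrying the free hydroxy group of compound 2, as this single step comes from one core only.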